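The compounds below may be only part of what the source reports. "The series", "measured", "known", "first", "only" and "open" are said of these compounds alone.

In a functional assay on SV5A8 cells (Homo sapiens) for cytotoxicity (on this read-out lower numbers stand for stronger inhibition and higher numbers for weaker inhibition), compound 2 `Cc1ccc2c(NCc3ccc(NC(=O)C4CCN(C(=O)OC(C)(C)C)CC4)cc3)nc(N(C)C)nc2c1` gives > 4820 nM, which is a limit of the assay rather than a number. For compound 1 `Cc1ccc2c(NCc3ccc(NC(=O)C4CCN(Cc5cccc(F)c5)CC4)cc3)nc(N(C)C)nc2c1` this assay gives > 4170 nM, again only a limit. For compound 3 `Cc1ccc2c(NCc3ccc(NC(=O)C4CCN(Cc5ccccc5)CC4)cc3)nc(N3CCC(N4CCCC4)CC3)nc2c1` this assay gives > 8090 nM, also a limit. Going by the values given here, the only single-site step among them, a step that the two limits leave unreadable from compound 1 to compound 2, therefore cannot be read in either direction, since compound 1 sits at the limit of > 4170 nM in this assay, at which 1 of the 3 values shown sits, and compound 2 at the limit of > 4820 nM in this assay, at which 1 of the 3 values shown sits; compound 3 likewise sits at the limit of > 8090 nM in this assay, at which 1 of the 3 values shown sits. The change to compound 4 `Cc1ccc2c(NCc3ccc(NC(=O)C4CCN(CC5CCNCC5)CC4)cc3)nc(N(C)C)nc2c1` is (piperidin-4-yl)methyl in place of tert-butoxycarbonyl on an amine nitrogen in a ring. Among the compounds with values here, no measured step covers this exchange, and none of the three values rises above a limit, so there is nothing that would point to a readable gain or loss. The expectation for compound 4 is a reading that again sits at a limit rather than a number, estimated at 8000 nM and expected to fall between 3000 nM and 30000 nM. The expected step that the limit leaves unreadable from compound 2 to compound 4 is thus estimated as no change beyond the scatter.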

Compound 4, half-maximal inhibitory concentration: > 8070 nM
Compound 4: only a limit was reported; the forecaster's own chance of this, stated with the estimate: 75%; middle value at least 1.0-fold (0.00 log units) from the limit.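

In this assay compound 4 gives > 8070 nM, which is a limit and not a number. Neither step to compound 4, from compound 1 or from compound 2, can be read. The compounds shown leave open whether the group on the amine nitrogen in a ring changes this read-out at all.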